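Swapping the fluorophenyl for a methyl ester bearing ring

The source may hold more compounds than are shown below. What is called first, only, known or untested is meant among the compounds shown, and "the series" means these compounds.

Three close relatives of one shared core have been tested in a functional assay on A549 cells (Homo sapiens) for cytotoxicity, read by sulforhodamine B assay, with a stated time of 72 h; a higher number here means a weaker inhibitor, a lower number a stronger inhibitor. Compound 1 `CCS(=O)(=O)Nc1cc(-c2ccc3ncnc(Nc4ccc(F)cc4)c3c2)cnc1OC` gives 7620 nM. Compound 2 `CCS(=O)(=O)Nc1cc(-c2ccc3ncnc(Nc4ccc(OC)cc4)c3c2)cnc1OC` gives 3580 nM, and compound 3 `CCS(=O)(=O)Nc1cc(-c2ccc3ncnc(Nc4ccc(OC)c(OC)c4)c3c2)cnc1OC` gives 5820 nM. Against these, compound 1 holds the top number: a 2.1-fold lower number from compound 1 to compound 2 (0.33 log units; beyond the scatter), whereas a 1.3-fold lower number from compound 1 to compound 3 (0.12 log units; within the scatter).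

Compound 4 `CCS(=O)(=O)Nc1cc(-c2ccc3ncnc(Nc4cccc(C(=O)OC)c4)c3c2)cnc1OC` is not yet measured. It differs from compound 1 by 3-(methoxycarbonyl)phenyl in place of 4-fluorophenyl on a nitrogen on an aromatic ring. Both earlier changes at this same ring either lowered the number modestly or left it within the scatter, so a similar modest drop, or none beyond the scatter, is expected here: a 1.5-fold lower number from compound 1 to compound 4 (0.18 log units; within the scatter). Compound 4 is therefore estimated at 5000 nM, with a plausible range from 2000 nM to 14000 nM.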

Compound 4, half-maximal inhibitory concentration: 1100 nM
Beside the measured number, compound 4's estimate is 4.5-fold (0.66 log units) above it; measured number below the stated range.
By their numbers in this assay, from the lowest: compound 4; then compounds 2, 3 and 1 (each within the scatter of the next, the first and the last beyond it).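

In this assay, changing the ring on this nitrogen can move the number much further than the earlier rings did: there is a 6.9-fold lower number from compound 1 to compound 4 (0.84 log units; beyond the scatter), along with a 5.3-fold lower number from compound 3 to compound 4 (0.72 log units; beyond the scatter) and a 3.3-fold lower number from compound 2 to compound 4 (0.51 log units; beyond the scatter). This makes compound 4 the strongest of the four, and it alone carries 3-(methoxycarbonyl)phenyl, with a carbonyl and two hydrogen-bond acceptors. Nothing shown explains this gain. The ester and its place on the ring change together, so their shares cannot be separated. A carboxylic acid or an amide on the same ring would show whether the ester itself matters.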